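Swapping the amine cap on a hydroxamic acid series

The compounds below may be only part of what the source reports. "The series", "measured", "known", "first", "only" and "open" are said of these compounds alone.

Measured so far:
- Compound 1 `CN(C)c1ccc(NC(=O)[C@H](CCCCCC(=O)NO)NC(=O)OCc2ccccc2)cc1`: 650 nM
- Compound 2 `O=C(CCCCC[C@H](NC(=O)OCc1ccccc1)C(=O)NC1CCCc2ccccc21)NO`: 1700 nM
- Compound 3 `O=C(CCCCC[C@H](NC(=O)c1ccc(C(F)(F)F)cc1)C(=O)Nc1cccc2cccnc12)NO`: 696 nM

In a functional assay on NFF cells (Homo sapiens) for antiproliferative activity (a lower number here means a stronger inhibitor, a higher number a weaker inhibitor), compound 3 gives 696 nM, the second highest of the three numbers; compound 1 lies within the scatter of it, while compound 2 sits beyond the scatter on the weaker side. Compound 4 `O=C(CCCCC[C@H](NC(=O)OCc1ccccc1)C(=O)Nc1cccc2cccnc12)NO` differs from compound 3 in one place: benzyloxy in place of 4-(trifluoromethyl)phenyl on a carbonyl carbon. Within the data shown here, the one measured step, a 2.6-fold higher number from compound 1 to compound 2 (0.42 log units; beyond the scatter), changes the group on the amide-type nitrogen instead, so it does not bear on this change. With no direct guide, the step of a 1.1-fold higher number from compound 3 to compound 4 (0.06 log units; within the scatter) is expected to stay within the scatter, and compound 4 is estimated at 800 nM, with a range of 300 nM to 2200 nM.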

Compound 4, half-maximal inhibitory concentration: 452 nM
Compound 4: the middle estimate sits 1.8-fold (0.25 log units) above what was measured, and the stated range covers the measured number.
By their numbers in this assay, from the lowest: compounds 4, 1 and 3 (each within the scatter of the next); then compound 2.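

Benzyloxy in place of 4-(trifluoromethyl)phenyl on a carbonyl carbon is tolerated in this assay, with a 1.5-fold lower number from compound 3 to compound 4 (0.19 log units; within the scatter). With benzyloxy kept, the group on the amide-type nitrogen can matter more: quinolin-8-yl gives a 3.8-fold lower number from compound 2 to compound 4 (0.58 log units; beyond the scatter) against 1,2,3,4-tetrahydronaphthalen-1-yl, but a 1.4-fold lower number from compound 1 to compound 4 (0.16 log units; within the scatter) against 4-(dimethylamino)phenyl. No measurement here offers an explanation for these steps.

The compounds shown leave open how a cyclohexyl or tert-butoxy group on the same carbonyl carbon would read in this assay.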